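Swapping Bromo for Nitro on a Piperazine Urea

This account rests on a few compounds, and the source may have more. Where it says the series, first, only, none or still open, it means among the compounds named here.

Measured so far in a functional assay on HEK293 cells for antagonist activity at transient receptor potential cation channel subfamily V member 1 (Rattus norvegicus); a higher number here means a weaker inhibitor, a lower number a stronger inhibitor:
- compound 1, `CCCCc1ccc(NC(=O)N2CCN(c3ncccc3Cl)CC2)cc1`: 203 nM
- compound 2, `O=C(Nc1ccc(Cl)cc1)N1CCN(c2ncccc2Cl)CC1`: 2670 nM
- compound 3, `O=C(Nc1ccc(Br)cc1)N1CCN(c2ncccc2Cl)CC1`: 1010 nM

All three share the same core and differ only in the group on one aromatic carbon of the six-membered carbon ring. Compound 3 stands second highest of the three numbers: it lies a 2.6-fold lower number from compound 2 to compound 3 (0.42 log units; beyond the scatter), and the other way a 5.0-fold higher number from compound 1 to compound 3 (0.70 log units; beyond the scatter). The halogen-bearing compounds are thus weaker than compound 1, and the gap a 13-fold higher number from compound 1 to compound 2 (1.12 log units; beyond the scatter) is the largest seen here.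

Compound 4, `O=C(Nc1ccc([N+](=O)[O-])cc1)N1CCN(c2ncccc2Cl)CC1`, is still unmeasured. Its change from compound 3 is nitro in place of bromo on an aromatic carbon. Within the data shown here, none of the measured steps replaces a halogen with a nitro group, so the closest guide is simply that the two halogens gave numbers well above compound 1, and that the swap from chloro to bromo moved the number by a modest amount. A nitro group is a different kind of substituent from either halogen, so the direction of the step is uncertain; a step of modest size in either direction, or none beyond the scatter, seems plausible.

For compound 4 the expected result in this assay is 1500 nM, with a range from 400 nM to 6000 nM, which would mean an expected step of a 1.5-fold higher number from compound 3 to compound 4 (0.17 log units; within the scatter).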

Compound 4, half-maximal inhibitory concentration: > 25000 nM
Compound 4 ended at the assay's limit (the forecaster's own chance of this, stated with the estimate: 10%); middle value at least 16-fold (1.22 log units) away from the limit.
By their numbers in this assay, from the lowest: compound 1; then compound 3; then compound 2. At a limit, above all of these: compound 4.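

In this assay, compound 4 reads > 25000 nM, which is a limit of the assay and not a number: the limit of > 25000 nM in this assay, at which 1 of the 4 values shown sits. The earlier compounds shown here showed this aromatic carbon tuning the number within a measurable range, but nitro, which brings 2 hydrogen-bond acceptors where bromo brings 0, gives an at least 24-fold higher number from compound 3 to compound 4 (1.39 log units; beyond the scatter), and the same comparison against the other two groups gives an at least 9.3-fold higher number from compound 2 to compound 4 (0.97 log units; beyond the scatter) and an at least 120-fold higher number from compound 1 to compound 4 (2.09 log units; beyond the scatter). Each of these steps is only a minimum, yet even the smallest of them exceeds a 2.6-fold lower number from compound 2 to compound 3 (0.42 log units; beyond the scatter) seen between the two halogens, so the choice of group at this place can matter far more than that halogen swap suggested.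

The data cannot say which difference between nitro and the other groups lies behind this loss, nor how far above the limit compound 4 truly sits. An amine, a methoxy group or a chain longer than butyl at the same carbon would show whether the low number of compound 1 can be improved and whether nitro stands alone in falling so far.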